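Thiourea series: butyl in place of 3-chlorophenyl

The source may report more compounds than this note shows. Statements on the series, on what has been measured and on what is new or still open speak of the compounds shown alone.

Measured compounds:
compound 1 `COc1cc2c(cc1OC)C(=O)C(CC1CCN(C(=S)Nc3cccc(C)c3)CC1)C2`: "not determined" (no result reported)
compound 2 `COc1cc2c(cc1OC)C(=O)C(CC1CCN(C(=S)Nc3ccc(C)cc3)CC1)C2`: 300 mg/kg
compound 3 `COc1cc2c(cc1OC)C(=O)C(CC1CCN(C(=S)Nc3cccc(Cl)c3)CC1)C2`: "not determined" (no result reported)

In a functional assay on the whole organism (strain Swiss albino) with Mus musculus as the target, with a stated time of 4 h (a higher number here means that more compound is needed for the effect, a lower number that less compound is needed), compound 2 gives 300 mg/kg. Compound 3 stands without a number in this assay, and the same holds for compound 1, so the series carries a single measured dose. Compound 4 `CCCCNC(=S)N1CCC(CC2Cc3cc(OC)c(OC)cc3C2=O)CC1` differs from compound 3 by butyl in place of 3-chlorophenyl on an amide-type nitrogen. No number for compound 3 exists, so no direction or size of step can be read from it in this assay. The expectation for compound 4 therefore rests on compound 2 alone, and no shift beyond the usual scatter of that dose is expected. Compound 4 is expected to give 300 mg/kg in this assay, with a range from 100 mg/kg to 1000 mg/kg.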

Compound 4, minimum effective dose: 300 mg/kg
For compound 4 middle estimate and measured number coincide at the digits printed; measured number inside the range.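

In this assay the step reads no change at the digits printed from compound 2 to compound 4 (within the scatter). At this position on an amide-type nitrogen, butyl thus takes the place of 4-methylphenyl without a step beyond the scatter, so within this pair a six-membered aromatic ring is not needed for a dose to be recorded. Steps involving compound 1 or compound 3 cannot be read, and no evidence bears on the result.

From the compounds shown here alone, whether a shorter ethyl chain, a longer octyl chain or a butyl chain ending in an amine would stay within the scatter remains open. The compounds shown also leave open how far this tolerance extends beyond this single pair.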